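The source may report more compounds than this note shows. Statements on the series, on what has been measured and on what is new or still open speak of the compounds shown alone.

Measured in a functional assay on MDA-MB-231 cells (Homo sapiens) for antiproliferative activity, read by MTT assay, with a stated time of 48 h; a lower number here means a stronger inhibitor of growth, a higher number a weaker inhibitor of growth:
- Compound 1 `COC(=O)N1N=C(c2ccccc2)CC1c1ccccc1`: > 10000 nM
- Compound 2 `COC(=O)N1N=C(c2ccccc2)CC1c1ccc(OC)c(O)c1`: 14500 nM

The entry for compound 1 is a limit of the assay and not a number. Within the data shown here, that leaves compound 2, at 14500 nM, with the only true number so far, and this number marks it as a weak inhibitor of growth.

Compound 3 `COC(=O)N1N=C(c2ccccc2)CC1c1ccc(OC)cc1` carries hydrogen in place of hydroxy on an aromatic carbon, ortho to a methoxy group: hydrogen in place of hydroxy on an aromatic carbon. Among the measured compounds shown here, no pair of measured compounds shows this change on its own, so the expectation in this assay is cautious: no step beyond the usual scatter, with a slight lean towards weaker inhibition. The expected change is a 1.2-fold higher number from compound 2 to compound 3 (0.09 log units; within the scatter). For compound 3 the estimated value is 18000 nM, with an expected range from 7000 nM to 45000 nM.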

Compound 3, concentration for 50% growth inhibition: > 10000 nM
Compound 3: only a limit was reported (the forecaster's own chance of this, stated with the estimate: 40%); the middle value is on the limit's open side.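

Among these compounds, compound 3 gives a limit of the assay and not a number, as compound 1 does, so no step from compound 1 or compound 2 to compound 3 can be read: the limit of > 10000 nM in this assay, at which 2 of the 3 values shown sit. Still open, as far as these compounds go, is how far compound 3 lies from compound 2 in this assay and so what the hydroxy group contributes.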